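Working notes: aryl change on the benzyl group of compound 1

This account rests on a few compounds, and the source may have more. Where it says the series, first, only, none or still open, it means among the compounds named here.

Measured so far:
compound 1 `Nc1nc(O)c2c(n1)n(C1OC(CO)[C@@H](O)[C@H]1O)c(=O)n2Cc1ccc(Cl)c(Cl)c1` — 110 uM
compound 2 `C=CCn1c(=O)n([C@@H]2O[C@H](CO)[C@H]3OC(=O)O[C@H]32)c2nc(N)nc(O)c21` — 20 uM

Both numbers come from a functional assay on YAC-1 cells (Mus musculus) for activation; on this read-out higher numbers stand for an effect only at larger amounts of compound and lower numbers for an effect already at smaller amounts. On this read-out compound 1 gives 110 uM, the higher of the two numbers. Compound 2 gives 20 uM, a lower number, and the gap between the two lies beyond the usual scatter. Compound 2 differs from compound 1 in more than one place, so the two values show only the overall distance and isolate no single change.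

The next compound, compound 3 `Nc1nc(O)c2c(n1)n(C1OC(CO)[C@@H](O)[C@H]1O)c(=O)n2Cc1ccc([N+](=O)[O-])cc1`, differs from compound 1 in one place only: 4-nitrophenyl in place of 3,4-dichlorophenyl on a saturated chain carbon bound to an aromatic nitrogen. Among the compounds with values here, no pair of measured compounds carries this same difference, so the step has no direct precedent here. Without such a precedent the step from compound 1 to compound 3 is expected to be small, a 1.1-fold lower number from compound 1 to compound 3 (0.04 log units; within the scatter), with no change beyond the scatter and its direction open. Compound 3 is therefore estimated at 100 uM, within a range of 30 uM to 300 uM.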

Compound 3, concentration for half-maximal effect: 48 uM
For compound 3 the middle estimate is 2.1-fold (0.32 log units) above the measured one, within the range that was stated.
By their numbers in this assay, from the lowest: compound 2; then compound 3; then compound 1.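

In this assay, within the data shown here, the first single-place comparison reads a 2.3-fold lower number from compound 1 to compound 3 (0.36 log units; beyond the scatter), so the aryl group on a saturated chain carbon bound to an aromatic nitrogen can shift the number, though only modestly here. The change swaps two chlorines for a nitro group and brings in two hydrogen-bond acceptors at once, so this step cannot assign the shift to any one of these features. No available data bear on the origin of the step.

As far as these compounds go, it remains open whether 4-chlorophenyl alone would give the number of compound 1 or that of compound 3. Also open, from the compounds shown here alone, is how an amine or a carboxylic acid on the phenyl ring, or a longer chain in place of the single saturated carbon, would read.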